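Notes on the substituent on the aromatic nitrogen

A few compounds are considered here, and "the series" means these few. Any claim that something is new, unique, unknown or untested is made for them only; others in the source may bear on it.

Measured compounds in a toxicity assay on HT-29 cells (Homo sapiens) for cytotoxicity; a higher number here means that more compound is tolerated, a lower number that less compound is tolerated:
Compound 1 `CCCn1nc(C(=O)N[C@H]2COc3ccccc3N(C)C2=S)nc1Cc1ccccc1` gives > 100000 nM, a limit of the assay.
Compound 2 `COCCn1nc(C(=O)N[C@H]2COc3ccccc3N(C)C2=S)nc1Cc1ccccc1` gives > 100000 nM, a limit of the assay.
Compound 3 `CN1C(=S)[C@@H](NC(=O)c2nc(Cc3ccccc3)n(CCCC#N)n2)COc2ccccc21` gives > 100000 nM, a limit of the assay.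

Compound 1 stands only at a limit, and the two further values shown are limits as well. The steps a step that the two limits leave unreadable from compound 1 to compound 2, a step that the two limits leave unreadable from compound 1 to compound 3 and a step that the two limits leave unreadable from compound 2 to compound 3 each alter the group on an aromatic nitrogen, and each is unreadable because of the limit of > 100000 nM in this assay, at which 3 of the 3 values shown sit. Compound 4 `CN1C(=S)[C@@H](NC(=O)c2nc(Cc3ccccc3)n(C3CCCCCC3)n2)COc2ccccc21` differs from compound 1 by cycloheptyl in place of propyl on an aromatic nitrogen. The three unreadable steps on an aromatic nitrogen bear on this change; none yields a size, so no step beyond the scatter is expected in this assay, and the same limit is expected again. Compound 4 is therefore estimated at 100000 nM (range 40000 nM to 300000 nM). The step of a number no higher from compound 1 to compound 4 (the limit leaves the size open) so estimated amounts to no change.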

Compound 4, half-maximal cytotoxic concentration: > 100000 nM
Compound 4 was reported as a limit; the forecaster's own chance of this, stated with the estimate: 70%; the middle value sits exactly at the limit.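

In this assay, compound 4 gives no readable step against compound 1, compound 2 or compound 3, because all four stand at one limit: the limit of > 100000 nM in this assay, at which 4 of the 4 values shown sit.

Whether any group on the aromatic nitrogen changes the half-maximal cytotoxic concentration remains open in the compounds shown.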